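The compounds below may be only part of what the source reports. "The series", "measured", "known", "first", "only" and "open" are said of these compounds alone.

The series shares the core of compound 1 `O=C(c1ccccc1)N(CCCCCCN1C[C@H](O)[C@@H](O)[C@H](O)[C@H]1CO)C1CCCCC1`, which carries a benzoyl on an amine nitrogen. In an ADME assay on MDBK cells (Bos taurus) for cytotoxicity, read by MTT assay (on this read-out lower numbers stand for higher toxicity in this test and higher numbers for lower toxicity in this test), compound 1 gives only a limit, > 500000 nM, and not a number. Compound 2 `O=S(=O)(c1ccccc1)N(CCCCCCN1C[C@H](O)[C@@H](O)[C@H](O)[C@H]1CO)C1CCCCC1` carries a phenylsulfonyl in place of the benzoyl on the amine nitrogen; in this assay compound 2 gives 200000 nM. Within the data shown here, the step of an at least 2.5-fold lower number from compound 1 to compound 2 (0.39 log units; beyond the scatter) is the sole measured step, and it is read against a limit (the limit of > 500000 nM in this assay, at which 1 of the 2 values shown sits). Among the measured compounds shown here, compound 2 thus holds the only number in this assay; the other value shown is a limit.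

Compound 3 `CC(C)(C)S(=O)(=O)N(CCCCCCN1C[C@H](O)[C@@H](O)[C@H](O)[C@H]1CO)C1CCCCC1` differs from compound 2 by tert-butyl in place of phenyl on a sulfonyl sulfur. For the measured compounds named here, no measured step alters the group on the sulfonyl sulfur; the single measured step swaps benzoyl for phenylsulfonyl on the amine nitrogen, a different place, and cannot be carried over. Going by the values given here, with no step bearing on this change, the expected step in this assay is no change at the digits printed from compound 2 to compound 3 (within the scatter), none beyond the scatter. Compound 3 is therefore estimated at 200000 nM, within 80000 nM to 500000 nM in this assay.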

Compound 3, half-maximal cytotoxic concentration: > 500000 nM
Compound 3 gave a limit, no number (the forecaster's own chance of this, stated with the estimate: 30%); middle value at least 2.5-fold (0.39 log units) away from the limit.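

The group on the sulfonyl sulfur matters in this assay: tert-butyl in place of phenyl gives an at least 2.5-fold higher number from compound 2 to compound 3 (0.39 log units; beyond the scatter), a change at this place that the earlier step on the amine nitrogen could not show. The lower number of compound 2 also cannot be assigned to the sulfonyl alone, as compound 3 carries a sulfonyl on the same amine nitrogen and yet gives no number. The step from compound 1 to compound 3 cannot be read, and the step into compound 3 gives only a floor, with both resting on a limit: the limit of > 500000 nM in this assay, at which 2 of the 3 values shown sit.

One pair of compounds does not separate the loss of the six-membered aromatic ring from the entry of the tert-butyl, and a methyl or a cyclohexyl on the sulfonyl sulfur would bear on that question. Also open, on these data alone, are the true size of the step and whether an amine or a carboxylic acid on the phenyl of compound 2 would shift the number in this assay.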